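Swapping methyl for ethoxycarbonyl on the ring amine

The source may report more compounds than this note shows. Statements on the series, on what has been measured and on what is new or still open speak of the compounds shown alone.

Among the measured compounds shown here, compound 1 `CN1CCc2ccccc2Cc2sc3ccccc3c2CC1` is the only compound here with a definite number: in an assay on isolated protein for binding affinity to D(1B) dopamine receptor (Homo sapiens), read by radioligand binding, with a stated time of 90 min (a lower number here means a stronger inhibitor, a higher number a weaker inhibitor), compound 1 gives 1.9 nM. Compound 2 `CCOC(=O)N1CCc2ccccc2Cc2ccsc2CC1` sits at the limit of > 1000 nM in this assay, at which 1 of the 2 values shown sits, a limit rather than a number: in this assay compound 2 gives > 1000 nM. Compound 3 `CCOC(=O)N1CCc2ccccc2Cc2sc3ccccc3c2CC1` is not yet measured; it differs from compound 1 by ethoxycarbonyl in place of methyl on an amine nitrogen in a ring. For the measured compounds named here, no measured pair shows this change directly, so its size rests on expectation alone. Compound 3 is expected to be much weaker, with a step of a 1100-fold higher number from compound 1 to compound 3 (3.02 log units; beyond the scatter) and an estimate of 2000 nM, ranging from 300 nM to 10000 nM.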

Compound 3, inhibition constant: > 1000 nM
Compound 3: no number, only a limit; the forecaster's own chance of this, stated with the estimate: 60%; the middle value lies beyond the limit too.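

In this assay, ethoxycarbonyl in place of methyl on the amine nitrogen in a ring gives an at least 520-fold higher number from compound 1 to compound 3 (2.72 log units; beyond the scatter). This is the first pair shown that differs in this one place alone, so the large loss of binding can be tied to this change on the core of compound 1. Compound 3 has only a limit, not a number, so the full size of the step stays unknown: the limit of > 1000 nM in this assay, at which 2 of the 3 values shown sit.

From the compounds shown here alone, it remains open how binding would respond to other groups on this nitrogen. An ethyl, an acetyl or a plain hydrogen could show whether strong binding survives anything larger than methyl or is lost only with ethoxycarbonyl.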